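This account rests on a few compounds, and the source may have more. Where it says the series, first, only, none or still open, it means among the compounds named here.

Measured compounds:
compound 1 `CCCCCCCCCC(=O)Nc1nnc(S[C@@H]2O[C@H](CO)[C@H](O)[C@H](O)[C@H]2O)s1` gives 25900 nM in a functional assay on HeLa cells (Homo sapiens) for cytotoxicity, read by MTT assay, with a stated time of 24 h; a higher number here means a weaker inhibitor, a lower number a stronger inhibitor
compound 2 `CCCCCCCC(=O)Nc1nnc(S[C@@H]2O[C@H](CO)[C@H](O)[C@H](O)[C@H]2O)s1` gives 50800 nM
compound 3 `CCCCCCCCCCCCCC(=O)Nc1nnc(S[C@@H]2O[C@H](CO)[C@H](O)[C@H](O)[C@H]2O)s1` gives 31000 nM

These three compounds share one core and differ only in the length of the saturated chain on the amide. In this assay compound 3 stands second highest of the three numbers, with compound 1 nearest and compound 2 furthest, and both of those gaps lie within the scatter. Compound 4 `CCCCCCCC/C=C\CCCCCCCCCCCC(=O)Nc1nnc(S[C@@H]2O[C@H](CO)[C@H](O)[C@H](O)[C@H]2O)s1` has not yet been measured. It differs from compound 3 by dec-1-en-1-yl in place of ethyl on a saturated chain carbon, ten or more bonds along the chain from a carbonyl carbon, so the chain grows longer and gains a double bond.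

For the measured compounds named here, the steps that bear on this are the chain-length changes already seen: a 2.0-fold higher number from compound 1 to compound 2 (0.29 log units; within the scatter), a 1.2-fold higher number from compound 1 to compound 3 (0.08 log units; within the scatter) and a 1.6-fold lower number from compound 2 to compound 3 (0.21 log units; within the scatter). None of them moves the number beyond the scatter, so lengthening the chain has so far left this assay essentially unchanged. The double bond is new and untested, but nothing measured points to a direction for it. The step from compound 3 to compound 4 is therefore expected to be small, a 1.0-fold lower number from compound 3 to compound 4 (0.01 log units; within the scatter). Compound 4 is estimated at 30000 nM, within a range from 12000 nM to 75000 nM.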

Compound 4, half-maximal inhibitory concentration: 13500 nM
For compound 4 the middle estimate is 2.2-fold (0.35 log units) above the measured one; low and high end bracket the measured number.
By their numbers in this assay, from the lowest: compounds 4, 1, 3 and 2 (each within the scatter of the next, the first and the last beyond it).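

In this assay, dec-1-en-1-yl in place of ethyl on a saturated chain carbon gives a 2.3-fold lower number from compound 3 to compound 4 (0.36 log units; beyond the scatter); unlike the steps among compounds 1, 2 and 3, this one lies beyond the scatter, though only modestly. Measured against a shorter saturated chain, the change gives a 1.9-fold lower number from compound 1 to compound 4 (0.28 log units; within the scatter), so compound 4 and compound 1 cannot be told apart in this assay. Compound 4 differs from compound 3 in both chain length and the double bond, and no measurement here accounts for the step.

The compounds shown leave open whether length or the double bond matters more, which a fully saturated chain of the same length or the trans form of the double bond could help to separate. They also leave open how the assay would respond to a chain ending in an amine or a carboxylic acid.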